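Benzyl ether series: cytotoxicity on Huh-5-2 cells

This account rests on a few compounds, and the source may have more. Where it says the series, first, only, none or still open, it means among the compounds named here.

Measured compounds:
- compound 1 `O=c1c(O)c(-c2ccccc2)oc2cc(OCc3ccccc3Cl)cc(O)c12`: > 100000 nM
- compound 2 `Cc1cccc(COc2cc(O)c3c(=O)c(O)c(-c4ccccc4)oc3c2)c1`: 35000 nM
- compound 3 `N#Cc1ccc(COc2cc(O)c3c(=O)c(O)c(-c4ccccc4)oc3c2)cc1`: 94000 nM

The three compounds share one core and differ only in the substituent on the benzyl ether. In an ADME assay on Huh-5-2 cells (Homo sapiens) for cytotoxicity, read by WST assay, with a stated time of 3 days (on this read-out higher numbers stand for lower toxicity in this test and lower numbers for higher toxicity in this test), compound 1 reaches only a limit of the assay, (the limit of > 100000 nM in this assay, at which 1 of the 3 values shown sits), and no number is known for it. Among the two numbers, compound 3 stands highest, with compound 2 nearest; the step of a 2.7-fold higher number from compound 2 to compound 3 (0.43 log units; beyond the scatter) lies beyond the scatter. The step of an at least 2.8-fold lower number from compound 1 to compound 2 (0.45 log units; beyond the scatter) is also beyond the scatter, whereas an at least 1.0-fold lower number from compound 1 to compound 3 (0.02 log units; that floor lies within the scatter) cannot be separated from it.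

Compound 4 `COc1ccc(COc2cc(O)c3c(=O)c(O)c(-c4ccccc4)oc3c2)cc1` is the next analogue to be tested. Its change from compound 3 is methoxy in place of cyano on an aromatic carbon. For the measured compounds named here, none of the measured steps swaps one substituent on this benzyl ring for another at the same place with the same pattern; the measured steps show only that changing this substituent moves this assay by small amounts, within or just beyond the scatter. The expectation is therefore a step of a 1.2-fold lower number from compound 3 to compound 4 (0.07 log units; within the scatter), small and of uncertain direction, possibly ending at the assay limit. Compound 4 is estimated at 80000 nM, in the range 35000 nM to 150000 nM.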

Compound 4, half-maximal cytotoxic concentration: > 100000 nM
Compound 4: no number, only a limit; the forecaster's own chance of this, stated with the estimate: 40%; middle value at least 1.2-fold (0.09 log units) away from the limit.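

In this assay compound 4 reaches > 100000 nM, which is a limit of the assay and not a number: the limit of > 100000 nM in this assay, at which 2 of the 4 values shown sit.

Methoxy in place of cyano on this aromatic carbon, para to a large group, gives an at least 1.0-fold higher number from compound 3 to compound 4 (0.02 log units; that floor lies within the scatter), so this floor does not separate the two groups, and the true size of the change remains unknown. Against the 3-methylphenyl of compound 2, the 4-methoxyphenyl gives an at least 2.8-fold higher number from compound 2 to compound 4 (0.45 log units; beyond the scatter), which leaves compound 2 as the one compound of the four whose steps to all the others are printed as beyond the scatter, with the lowest number in the set.

From the compounds shown here alone, the step between compound 1 and compound 4 cannot be read, since both stand at the limit, and how far either lies past it stays unknown. Also open, going by these compounds, is whether the lower number of compound 2 belongs to the methyl group or to its place on the ring, and whether an amine or a carboxylic acid on the benzyl ring would move this read-out at all.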